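The source may report more compounds than this note shows. Statements on the series, on what has been measured and on what is new or still open speak of the compounds shown alone.

Of the compounds shown here, three sharing one core have been measured in a functional assay on NIH3T3 cells (Mus musculus); on this read-out lower numbers stand for an effect already at smaller amounts and higher numbers for an effect only at larger amounts of compound: compound 1 `Cn1cncc1C(OCc1ccc(C#N)cc1-c1ccccc1)c1ccc(C#N)cc1` gives 140 nM, compound 2 `Cn1cncc1C(OCc1ccc(C#N)cc1/C=C/c1ccc([N+](=O)[O-])cc1)c1ccc(C#N)cc1` gives 2.24 nM, and compound 3 `Cn1cncc1C(OCc1ccc(C#N)cc1C#Cc1ccccc1)c1ccc(C#N)cc1` gives 0.1 nM, the lowest of the three numbers. Compound 4 `Cn1cncc1C(OCc1ccc(C#N)cc1-c1ccc(C#N)cc1)c1ccc(C#N)cc1` has 4-cyanophenyl in place of 2-phenylethynyl on an aromatic carbon. The most relevant evidence is the large step of a 1400-fold lower number from compound 1 to compound 3 (3.15 log units; beyond the scatter), which came with 2-phenylethynyl replacing phenyl, while the step of a 22-fold lower number from compound 2 to compound 3 (1.35 log units; beyond the scatter) is also large. From the compounds shown here alone, the incoming 4-cyanophenyl is closest to the phenyl of compound 1, at 140 nM, though the effect of its added nitrile is untested. A large step towards a higher number is therefore expected in this assay, an estimated 400-fold higher number from compound 3 to compound 4 (2.60 log units; beyond the scatter). For compound 4 the estimated value is 40 nM, with a range from 5 nM to 300 nM.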

Compound 4, half-maximal effective concentration: < 0.1 nM
Compound 4 ended at the assay's limit; the forecaster's own chance of this, stated with the estimate: 3%; at least 400-fold (2.60 log units) between middle value and limit.
By their numbers in this assay, from the lowest: compound 3; then compound 2; then compound 1.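

In this assay compound 4 gives < 0.1 nM, which is a limit of the assay and not a number. Cyano in place of hydrogen on the phenyl gives an at least 1400-fold lower number from compound 1 to compound 4 (3.14 log units; beyond the scatter), and the comparison with the nitrophenyl-bearing compound gives an at least 22-fold lower number from compound 2 to compound 4 (1.35 log units; beyond the scatter), so this position reaches the low end of the read-out with a ring attached directly, without an ethynyl or ethenyl link. The remaining step is a number no higher from compound 3 to compound 4 (the limit leaves the size open), and its size cannot be read because the value it ends on sits at the limit: the limit of < 0.1 nM in this assay, at which 1 of the 4 values shown sits.

From the compounds shown here alone, what stays open is whether the nitrile itself is needed. An amine or a carboxylic acid in its place on the phenyl could give a very different number.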